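A Furan-to-Chlorophenyl Swap at the Double-Bonded Chain Carbon

A few compounds are considered here, and "the series" means these few. Any claim that something is new, unique, unknown or untested is made for them only; others in the source may bear on it.

All values come from a functional assay on SJ-G2 cells (Homo sapiens) for inhibition, read by MTT assay, with a stated time of 72 h; on this read-out lower numbers stand for stronger inhibition of growth and higher numbers for weaker inhibition of growth.
Compound 1 `N#C/C(=C\c1c(F)c(F)c(F)c(F)c1F)C(=O)c1ccc[nH]1` gives 23000 nM.
Compound 2 `N#C/C(=C\c1ccc[nH]1)C(=O)NCc1ccc(Cl)c(Cl)c1` gives > 50000 nM, which is a limit of the assay and not a number.
Compound 3 `N#C/C(=C\c1ccco1)C(=O)NCc1ccc(Cl)c(Cl)c1` gives > 50000 nM, again a limit rather than a number.

Compound 3 therefore stands at the edge of what this assay can report, and only compound 1 carries a real number. Going by the values given here, the single one-place change among the measured compounds, a step that the two limits leave unreadable from compound 2 to compound 3, cannot be read because both of its values sit at the same limit (the limit of > 50000 nM in this assay, at which 2 of the 3 values shown sit). Compound 4 `N#C/C(=C\c1ccc(Cl)cc1)C(=O)NCc1ccc(Cl)c(Cl)c1` differs from compound 3 in one place: 4-chlorophenyl in place of furan-2-yl on a double-bonded chain carbon bound to a double-bonded chain carbon. Among the compounds with values here, no measured step shows what replacing a five-membered ring with a six-membered ring does here, and compound 1 differs from compound 4 in more than one place, so it only shows that the series as a whole inhibits growth weakly. The step of an at least 1.4-fold lower number from compound 3 to compound 4 (0.15 log units; that floor lies within the scatter) is therefore expected to be no larger than the scatter, with a fair chance that the assay again reports only a limit. Compound 4 is estimated at 35000 nM, in a range from 10000 nM to 50000 nM.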

Compound 4, concentration for 50% growth inhibition: 30000 nM
The estimate for compound 4 lay 1.2-fold (0.07 log units) above the measured number; the measured number falls inside the stated range.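

In this assay, going by these compounds alone, compound 4 is the only one of compounds 2, 3 and 4 to give a real number instead of a limit, so a six-membered carbon ring bearing chlorine on the double-bonded chain carbon gives the first readable value for this amide side chain. Putting 4-chlorophenyl in place of furan-2-yl gives an at least 1.6-fold lower number from compound 3 to compound 4 (0.22 log units; that floor lies within the scatter), and putting it in place of 1H-pyrrol-2-yl gives an at least 1.6-fold lower number from compound 2 to compound 4 (0.22 log units; that floor lies within the scatter), so neither step shows a change larger than the scatter, although the true steps could be larger. The step between the two five-membered rings cannot be read, and the two new steps have no upper end, because their starting compounds sit at a limit: the limit of > 50000 nM in this assay, at which 2 of the 4 values shown sit.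

As far as these compounds go, what remains open is whether the larger ring or its chlorine accounts for the readable value, a question that a plain phenyl group at this place would help to separate. From the compounds shown here alone, it is also open whether a methoxy group or a carboxylic acid in place of that chlorine would move the number beyond the scatter.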